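Cytotoxicity series: a chloro step on the benzoyl ring

The source may hold more compounds than are shown below. What is called first, only, known or untested is meant among the compounds shown, and "the series" means these compounds.

The series is followed in a functional assay on HepG2 cells (Homo sapiens) for cytotoxicity, read by MTT assay, with a stated time of 48 h; a lower number here means a stronger inhibitor, a higher number a weaker inhibitor. Compound 1 `C=CCSc1nnc(CC)n1N1C(=O)c2ccccc2C1=O` gives > 200000 nM, which is a limit of the assay and not a number. Compound 2 `CCc1nnc(SCC(=O)c2ccccc2)n1N1C(=O)c2ccccc2C1=O` gives > 200000 nM, again a limit of the assay rather than a measured number. The change between the two, benzoyl in place of vinyl on a saturated chain carbon bound to a sulfur, gives a step that the two limits leave unreadable from compound 1 to compound 2; both values sit at the limit of > 200000 nM in this assay, at which 2 of the 2 values shown sit, so the size of this step cannot be read. Compound 2 therefore stands at the limit in this assay, with no number of its own on the scale.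

Compound 3 `CCc1nnc(SCC(=O)c2ccc(Cl)cc2)n1N1C(=O)c2ccccc2C1=O` differs from compound 2 by chloro in place of hydrogen on an aromatic carbon. Within the data shown here, the only measured step, the one from compound 1 to compound 2, is unreadable, so no step size in this assay can be drawn from it to bear on this change. Since both measured values sit at the limit, the step from compound 2 to compound 3 is expected to be a step that the limit leaves unreadable from compound 2 to compound 3 in this assay, with no direction readable. Compound 3 is expected to give about 250000 nM in this assay, within a range from 100000 nM to 700000 nM, and most likely again only a limit will be reported.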

Compound 3, half-maximal inhibitory concentration: > 200000 nM
Compound 3 ended at the assay's limit; the forecaster's own chance of this, stated with the estimate: 80%; the middle value does not contradict the limit.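

No step can be read among compound 1, compound 2 and compound 3 in this assay, because none of the three has a number of its own on the scale: the limit of > 200000 nM in this assay, at which 3 of the 3 values shown sit.

The compounds shown leave open whether the chloro change, or the change from vinyl to benzoyl, alters cytotoxicity in this series at all.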